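This account rests on a few compounds, and the source may have more. Where it says the series, first, only, none or still open, it means among the compounds named here.

Three compounds from the same family share a ring that holds two neighbouring oxygen atoms, with a short acid-bearing side chain attached to it, and differ in the hydrocarbon tail on the other side. Compound 1 `CC1=C(CC/C(C)=C/CC[C@@]2(C)CC[C@@H]([C@H](C)C(=O)O)OO2)C(C)(C)CCC1` carries a tail with an open chain and a single ring. In a functional assay on SK-MEL-2 cells (Homo sapiens) for inhibition (a lower number here means a stronger inhibitor of growth, a higher number a weaker inhibitor of growth), compound 1 gives > 100000 nM, which is a limit of the assay and not a measured number. Compound 2 `C=C1CCCC(C)(C)C1CC[C@@]1(C)CC[C@H]([C@@H](C)C(=O)O)OO1` has a shorter tail with one ring and gives 5060 nM in this assay. Compound 3 `C=C1CCC[C@H]2[C@](C)(CC[C@]3(C)CC[C@H]([C@@H](C)C(=O)O)OO3)[C@@H](C)CC[C@]12C` has a tail of two fused rings and gives 2170 nM in this assay. Compound 1 therefore stands apart from the other two, since its value is the one that sits at the limit (the limit of > 100000 nM in this assay, at which 1 of the 3 values shown sits).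

Among the compounds with values here, compound 4 `CC1=C(CC/C(C)=C/CC[C@@]2(C)CC[C@H]([C@H](C)C(=O)O)OO2)C(C)(C)CCC1` is the untested partner of compound 1. the two compounds have the same atoms and bonds and differ only in configuration as drawn: 1 of 4 stereo elements differ; a stereocentre at a saturated ring carbon is drawn S in compound 1 and R in compound 4 No measured pair of this kind is available to guide the step, so the direction is uncertain. Compound 1 itself gives only a limit, and the two measured analogues show that this ring system can be active in the low micromolar range, so a change into measurable growth inhibition is expected but with wide uncertainty. Compound 4 is estimated at 20000 nM, expected to lie between 3000 nM and 100000 nM, a step of an at least 5.0-fold lower number from compound 1 to compound 4 (0.69 log units; beyond the scatter).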

Compound 4, concentration for 50% growth inhibition: > 5000 nM
Compound 4 was reported as a limit (the forecaster's own chance of this, stated with the estimate: 40%); the middle value does not contradict the limit.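

In this assay compound 4 gives > 5000 nM, which is a limit of the assay and not a number. Compound 1 also gives only a limit, and no step can be read between compound 1 and compound 4. On these data alone, whether the one stereocentre that differs between these two compounds changes growth inhibition stays open.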